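Swapping the distal para substituent on a biaryl amide

The compounds below may be only part of what the source reports. "The series", "measured", "known", "first", "only" and "open" are said of these compounds alone.

Measured compounds:
compound 1 `CC[C@H](C)[C@H](N)CN(C(=O)[C@@H]1C[C@H]1c1ccccc1)c1ccc(-c2ccc(C(F)(F)F)cc2)cc1` — 340 nM
compound 2 `CCOC(=O)c1ccc(-c2ccc(N(C[C@@H](N)[C@@H](C)CC)C(=O)[C@@H]3C[C@H]3c3ccccc3)cc2)cc1` — 260 nM

In a functional assay for agonist activity at G protein-coupled receptor 88 (Homo sapiens), read by HTRF and cAMP accumulation (on this read-out lower numbers stand for an effect already at smaller amounts and higher numbers for an effect only at larger amounts of compound), compound 2 gives 260 nM, and in this assay compound 1 gives 340 nM; the two values lie within the scatter of each other, so neither can be called the more potent. Compound 3 `CC[C@H](C)[C@H](N)CN(C(=O)[C@@H]1C[C@H]1c1ccccc1)c1ccc(-c2ccc(NC(C)=O)cc2)cc1` is not yet measured. It differs from compound 2 by acetamido in place of ethoxycarbonyl on an aromatic carbon. For the measured compounds named here, the only measured step that bears on this position is a 1.3-fold lower number from compound 1 to compound 2 (0.12 log units; within the scatter), a swap at the same aromatic carbon that left the number essentially unchanged. Going by the values given here, no measured step covers an acetamido group, so the expectation for compound 3 rests on that single exchange being tolerated. Compound 3 is therefore expected to show a 1.3-fold higher number from compound 2 to compound 3 (0.13 log units; within the scatter), no more than the scatter. Compound 3 is estimated at 350 nM, with a range from 140 nM to 900 nM.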

Compound 3, half-maximal effective concentration: 5500 nM
Estimate against measurement, compound 3: 16-fold (1.20 log units) below; the measured number lies above the stated range.
By their numbers in this assay, from the lowest: compounds 2 and 1 (each within the scatter of the next); then compound 3.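

In this assay this position, on an aromatic carbon para to a large group, proves far from indifferent to what it carries: acetamido in place of ethoxycarbonyl gives a 21-fold higher number from compound 2 to compound 3 (1.33 log units; beyond the scatter) and acetamido in place of trifluoromethyl gives a 16-fold higher number from compound 1 to compound 3 (1.21 log units; beyond the scatter) while the exchange between the other two groups gave only a 1.3-fold lower number from compound 1 to compound 2 (0.12 log units; within the scatter). The agreement of compound 1 and compound 2 therefore does not extend to every group here, and compound 3 stands apart from both. By count, acetamido carries a hydrogen-bond donor where ethoxycarbonyl carries none, but nothing available ties the change in potency to that or any other feature of the group.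

On these data alone, whether the amide hydrogen matters remains open. The compounds shown also do not tell how a primary amine, a carboxylic acid, a methyl ether or a longer ester chain would read at this position.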